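This account rests on a few compounds, and the source may have more. Where it says the series, first, only, none or still open, it means among the compounds named here.

Working notes on the series. Compound 1 `COc1c(OCCCCN2CCN(C)CC2)cc(O)c2c(=O)cc(-c3ccc([N+](=O)[O-])cc3)oc12`, compound 2 `CN(C)CCCOc1c(OCc2ccccc2)cc(O)c2c(=O)cc(-c3ccccc3)oc12` and compound 3 `CCN(CC)CCCOc1c(OCc2ccccc2)cc(O)c2c(=O)cc(-c3ccccc3)oc12` share one core. In a functional assay on HepG2 cells (Homo sapiens) for cytotoxicity, read by MTT assay, with a stated time of 72 h (a higher number here means a weaker inhibitor, a lower number a stronger inhibitor), compound 1 gives 2620 nM, compound 2 gives 4950 nM and compound 3 gives 3010 nM; compound 3 lies within the scatter of both compound 1 and compound 2, so the three numbers cannot be told apart. Compound 4 `O=c1cc(-c2ccccc2)oc2c(OCCCN3CCCC3)c(OCc3ccccc3)cc(O)c12` awaits measurement. The change is pyrrolidin-1-yl in place of diethylamino on a saturated chain carbon, three bonds along the chain from an oxygen on an aromatic ring. Within the data shown here, the one measured step at this place, a 1.6-fold lower number from compound 2 to compound 3 (0.22 log units; within the scatter), stayed within the scatter, so swapping one amine for another here has not yet moved this assay in a readable way. For compound 4 no step beyond the scatter is therefore expected, a 1.0-fold lower number from compound 3 to compound 4 (0.00 log units; within the scatter). Compound 4 is estimated at 3000 nM, with a range from 1500 nM to 6000 nM.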

Compound 4, half-maximal inhibitory concentration: 2660 nM
Compound 4: the middle estimate sits 1.1-fold (0.05 log units) above what was measured, and the stated range covers the measured number.
By their numbers in this assay, from the lowest: compounds 1, 4, 3 and 2 (each within the scatter of the next).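

In this assay, a ring-bearing amine now stands at this place: a 1.1-fold lower number from compound 3 to compound 4 (0.05 log units; within the scatter) and a 1.9-fold lower number from compound 2 to compound 4 (0.27 log units; within the scatter) both stay within the scatter. Pyrrolidin-1-yl therefore cannot be told apart from diethylamino or dimethylamino on this chain, so closing the amine into a five-membered ring has no readable effect here. No measurement is at hand that could explain this result.

On these data alone, whether piperidin-1-yl, morpholin-4-yl or a carboxylic acid at the chain end would move the number beyond the scatter stays open. So does the effect of a longer chain carrying pyrrolidin-1-yl.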